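The source may report more compounds than this note shows. Statements on the series, on what has been measured and on what is new or still open speak of the compounds shown alone.

Of the compounds shown here, three have been tested in a functional assay on DU-145 cells (Homo sapiens) for inhibition, read by trypan blue exclusion, with a stated time of 96 h; on this read-out lower numbers stand for stronger inhibition of growth and higher numbers for weaker inhibition of growth. Compound 1 `Cc1ccc(S/C(=C/c2ccc(N(C)C)cc2)C(=O)c2ccc(Cl)cc2)cc1` carries a 4-(dimethylamino)phenyl group on a double-bonded chain carbon bound to a double-bonded chain carbon. In this assay compound 1 gives no number, only > 100000 nM, which is the limit of > 100000 nM in this assay, at which 1 of the 3 values shown sits. Compound 2 `COc1ccc(/C=C(/Sc2ccc(C)cc2)C(=O)c2ccc(Cl)cc2)cc1O` shares the core of compound 1 and differs in a single place: 3-hydroxy-4-methoxyphenyl in place of 4-(dimethylamino)phenyl on a double-bonded chain carbon bound to a double-bonded chain carbon. In this assay compound 2 gives 1000 nM. That one exchange gives an at least 100-fold lower number from compound 1 to compound 2 (2.00 log units; beyond the scatter).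

Compound 3 `CN(C)c1ccc(/C=C(/SCc2ccc(F)cc2)C(=O)c2ccc(Br)cc2)cc1` has a different core; how it differs from compound 1 is not broken down here. In this assay, going by the values given here, compound 3 gives 50000 nM, the higher of the two numbers measured so far. Compound 4 `COc1ccc(/C=C(/SCc2ccc(F)cc2)C(=O)c2ccc(Br)cc2)cc1O`, not yet measured, differs from compound 3 by the same exchange: 3-hydroxy-4-methoxyphenyl in place of 4-(dimethylamino)phenyl on a double-bonded chain carbon bound to a double-bonded chain carbon. The place is described in the same words in both cases, so this is the same change.

Whether the exchange lowers the number as strongly on the core of compound 3 cannot be read directly from compound 1 and compound 2, since compound 3 differs from compound 1 in more than one place. Still, a large step is expected, a 33-fold lower number from compound 3 to compound 4 (1.52 log units; beyond the scatter), because the same change gave an at least 100-fold lower number from compound 1 to compound 2 (2.00 log units; beyond the scatter). On that basis compound 4 is estimated to give 1500 nM in this assay, expected to fall between 300 nM and 10000 nM.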

Compound 4, concentration for 50% growth inhibition: 1000 nM
Compound 4: middle estimate off by 1.5-fold (0.18 log units), on the high side; the measured number falls inside the stated range.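

In this assay, putting 3-hydroxy-4-methoxyphenyl in place of 4-(dimethylamino)phenyl on a double-bonded chain carbon bound to a double-bonded chain carbon gives a 50-fold lower number from compound 3 to compound 4 (1.70 log units; beyond the scatter), so the exchange also brings a large drop in the number on this second core. Set side by side, the two steps run in the same direction and both are large, and the comparison can be stated only this far: the same change on two cores in this assay, an at least 100-fold lower number (2.00 log units; beyond the scatter) from compound 1 to compound 2 and a 50-fold lower number (1.70 log units; beyond the scatter) from compound 3 to compound 4; the limit leaves it open whether they differ Two cores show that the change carried over in these two cases, not that it will do so on every core of the series, and the earlier step rests on compound 1, whose entry is a limit and not a number: the limit of > 100000 nM in this assay, at which 1 of the 4 values shown sits.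

The compounds shown leave open which part of the entering group matters, since a phenyl ring carrying only the hydroxyl group or only the methoxy group does not appear among them. They also leave open how a quite different group at the same place, such as a carboxylic acid or a simple amine, would behave on either core, so the exchange is known here only as a swap of these two whole groups.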